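The source may hold more compounds than are shown below. What is called first, only, known or untested is meant among the compounds shown, and "the series" means these compounds.

Measured compounds:
compound 1 `COC(=O)/C=C/c1cccc(N(Cc2ccc(/C=C/c3ccccn3)cc2)C(=O)C(C)C)c1`, 310 nM
compound 2 `COC(=O)/C=C/c1cccc(N(Cc2ccc(-c3ccc(F)c(Cl)c3)cc2)C(=O)C2CCCCC2)c1`, 66 nM
compound 3 `COC(=O)/C=C/c1cccc(N(Cc2ccc(/C=C/C(=O)OC(C)(C)C)cc2OCc2ccccc2)C(=O)C2CCCCC2)c1`, > 1000 nM

Of the compounds shown here, three that share a core have been tested in an assay on isolated protein with Bile acid receptor (Homo sapiens) as the target; on this read-out higher numbers stand for an effect only at larger amounts of compound and lower numbers for an effect already at smaller amounts. Compound 2 gives the lowest of the two numbers, at 66 nM. Compound 1, the nearest, gives 310 nM, a higher number that lies beyond the usual scatter. For compound 3 the assay reports only a limit, > 1000 nM, and no number. That limit is marked as the limit of > 1000 nM in this assay, at which 1 of the 3 values shown sits. No pair among these three differs in a single place, so no measured step is known.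

Compound 4 `COC(=O)/C=C/c1cccc(N(Cc2ccc(/C=C/c3c(Cl)cccc3Cl)cc2)C(=O)C2CCCCC2)c1` has not yet been measured. It differs from compound 2 in one place: 2-(2,6-dichlorophenyl)ethenyl in place of 3-chloro-4-fluorophenyl on an aromatic carbon. Without a measured step of this kind, the expectation rests on the spread between compound 2 and compound 1. The expected step from compound 2 to compound 4 in this assay is a modest rise, a 1.7-fold higher number from compound 2 to compound 4 (0.22 log units; within the scatter), within or close to the scatter. Compound 4 is thus estimated at 110 nM, with a range from 35 nM to 400 nM.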

Compound 4, half-maximal effective concentration: 150 nM
Beside the measured number, compound 4's estimate is 1.4-fold (0.13 log units) below it; the range from low to high includes it.
By their numbers in this assay, from the lowest: compound 2; then compound 4; then compound 1. At a limit, above all of these: compound 3.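

In this assay, the place on the shared core that holds 3-chloro-4-fluorophenyl now has its first measured step: putting 2-(2,6-dichlorophenyl)ethenyl there gives a 2.3-fold higher number from compound 2 to compound 4 (0.36 log units; beyond the scatter). The step is modest, so this place accepts an aromatic ring set on an ethenyl link, and with it more heavy atoms, at only a small cost, although the directly attached ring of compound 2 keeps the lower number. The data shown give no explanation for this rise.

Open, from the compounds shown here alone, is whether the rise belongs to the ethenyl link or to the change of halogens on the ring, since both change together in this step. Also open, going by these compounds, is how a carboxylic acid or an amine at this place would read in this assay.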